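A Halogen Swap on the Way to Compound 3

The source may report more compounds than this note shows. Statements on the series, on what has been measured and on what is new or still open speak of the compounds shown alone.

Of the compounds shown here, two have so far been tested in an ADME assay on MCF-10A cells (Homo sapiens) for cytotoxicity, read by sulforhodamine B assay, with a stated time of 48 h; on this read-out higher numbers stand for weaker inhibition of growth and lower numbers for stronger inhibition of growth. Compound 1 `O=C1C(=O)N(CN2CCN(c3ccnc4cc(C(F)(F)F)ccc34)CC2)c2cccc(Cl)c21` gives 24000 nM in this assay. Compound 2 `NC(=S)N/N=C1/C(=O)N(CN2CCN(c3ccnc4cc(Cl)ccc34)CC2)c2cc(Cl)ccc21` gives 64600 nM in this assay; this is the higher of the two numbers, so compound 2 holds back the growth of these cells more weakly than compound 1, and the gap between the two lies beyond the usual scatter of repeated measurements.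

Compound 3 `NC(=S)N/N=C1/C(=O)N(CN2CCN(c3ccnc4cc(Cl)ccc34)CC2)c2cc(Br)ccc21` has not yet been measured. It differs from compound 2 in one place only: bromo in place of chloro on an aromatic carbon. Among the measured compounds shown here, no pair of measured compounds shows what this swap does in this assay, so there is no directly comparable step to lean on. With nothing measured to point either way, the expected step is none beyond the scatter, in no firm direction.

Compound 3 is therefore expected to give about 60000 nM in this assay, within a range from 28000 nM to 130000 nM. The step from compound 2 to compound 3 that this estimate implies is a 1.1-fold lower number from compound 2 to compound 3 (0.03 log units; within the scatter), which is expected to stay within the usual scatter.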

Compound 3, concentration for 50% growth inhibition: 22100 nM
Compound 3: the middle estimate sits 2.7-fold (0.43 log units) above what was measured; the measured number lies below the stated range.
By their numbers in this assay, from the lowest: compounds 3 and 1 (each within the scatter of the next); then compound 2.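

Bromo in place of chloro on this aromatic carbon produces, in this assay, a 2.9-fold lower number from compound 2 to compound 3 (0.47 log units; beyond the scatter) and so moves the read-out towards stronger inhibition of growth. Among the compounds shown here, this is the first step that changes one place only, whereas compound 1 and compound 2 differ in several places at once and could not show what any single group contributes. The step is modest, yet it shows that the growth of these cells responds to which halogen sits on this carbon, even though the rest of the molecule stays the same, but nothing measured here explains why the exchange of one halogen for the other has this result.

A single pair cannot say whether the trend continues beyond bromo, and fluoro, iodo, methyl, methoxy or an amine on the same carbon would show whether the read-out follows a wider pattern or belongs to bromo alone. On these data alone, it also remains open whether the same swap would give a similar step at the chloro that compound 2 and compound 3 share, or on a molecule with a different core.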